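Removing the Amino Group from a Lipid-Linked Vanillyl Amide

The source may report more compounds than this note shows. Statements on the series, on what has been measured and on what is new or still open speak of the compounds shown alone.

Compound 1 `CCCCCCCC/C=C\CCCCCCCCSC[C@H](N)C(=O)NCc1ccc(O)c(OC)c1` is tested in an assay on HEK293 cells for antagonist activity at transient receptor potential cation channel subfamily V member 2 (Rattus norvegicus), read by fluorescence and calcium flux, with a stated time of 5 min (on this read-out higher numbers stand for weaker inhibition and lower numbers for stronger inhibition), where compound 1 gives 1900 nM. Compound 2 `CCCCCCCCCCCCCCCC[Se]C[C@H](N)C(=O)NCc1ccc(O)c(OC)c1` gives 1200 nM in this assay, and the two numbers lie within the usual scatter of one another. Compound 3 `CCCCCCCC/C=C\CCCCCCCCSCCC(=O)NCc1ccc(O)c(OC)c1` differs from compound 1 by hydrogen in place of amino on a saturated chain carbon bound to a carbonyl carbon and a saturated chain carbon. Among the compounds with values here, no measured pair shows this change, so only a small step, if any beyond the scatter, is expected, a 1.6-fold higher number from compound 1 to compound 3 (0.20 log units; within the scatter). Compound 3 is estimated at 3000 nM, between 1200 nM and 8000 nM.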

Compound 3, half-maximal inhibitory concentration: 2500 nM
Beside the measured number, compound 3's estimate is 1.2-fold (0.08 log units) above it; measured number inside the range.
By their numbers in this assay, from the lowest: compounds 2, 1 and 3 (each within the scatter of the next, the first and the last beyond it).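

In this assay, hydrogen in place of amino on a saturated chain carbon bound to a carbonyl carbon and a saturated chain carbon gives a 1.3-fold higher number from compound 1 to compound 3 (0.12 log units; within the scatter). At this position, then, the amino group is not needed for a reading in the range of compound 1. No available evidence bears on this result. On these data alone, whether a dimethylamino group or a carboxylic acid on this carbon would read alike remains open. So does whether losing the amino group would give the same outcome with the selenium-linked chain of compound 2.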